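Swapping a Bicyclic Aryl Group: Expected Solubility Shift

The source may hold more compounds than are shown below. What is called first, only, known or untested is meant among the compounds shown, and "the series" means these compounds.

Measured so far:
compound 1 `CCc1ccc(-c2nc3c(c(C)nn3-c3ccccc3)c(-c3ccccc3C)c2C#N)cc1` — 6000 nM
compound 2 `Cc1nn(-c2ccccc2)c2nc(-c3ccc4ccccc4c3)c(C#N)c(-c3ccccc3O)c12` — 1800 nM

In a physicochemical assay for solubility, read by spectrophotometry, in phosphate buffer, with a stated time of 18 h, at pH 7.4 (a lower number here means a less soluble compound, a higher number a more soluble compound), compound 2 gives 1800 nM, the lower of the two numbers recorded so far, while compound 1 gives 6000 nM, a gap that lies beyond the usual scatter. Compound 3 `Cc1nn(-c2ccccc2)c2nc(-c3ccc4c(c3)OCCO4)c(C#N)c(-c3ccccc3O)c12` has not yet been measured. It differs from compound 2 in one place: 2,3-dihydro-1,4-benzodioxin-6-yl in place of naphthalen-2-yl on an aromatic carbon. Going by the values given here, no measured pair shows this exact change, so nothing here serves as a direct guide to its size. Still, an increase beyond the scatter is expected, roughly a 2.2-fold higher number from compound 2 to compound 3 (0.35 log units; beyond the scatter). For compound 3 the estimated solubility is therefore 4000 nM, with a likely range of 1500 nM to 12000 nM.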

Compound 3, solubility: 11000 nM
The estimate for compound 3 lay 2.8-fold (0.44 log units) below the measured number, and the stated range covers the measured number.
By their numbers in this assay, from the lowest: compound 2; then compounds 1 and 3 (each within the scatter of the next).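

In this assay, going by these compounds alone, putting 2,3-dihydro-1,4-benzodioxin-6-yl in place of naphthalen-2-yl gives a 6.1-fold higher number from compound 2 to compound 3 (0.79 log units; beyond the scatter), the first change in one place seen here. This shows that the read-out responds to the group at this aromatic carbon, even with the heavy-atom count unchanged and oxygen replacing some of the carbon. Nothing available explains the rise.

From the compounds shown here alone, it remains open how a methoxyphenyl group or a morpholine would compare at this position. Going by these compounds, it is also open whether the same swap would give a similar step on a different core.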